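This account rests on a few compounds, and the source may have more. Where it says the series, first, only, none or still open, it means among the compounds named here.

In an ADME assay on HEK293 cells (Homo sapiens) for cytotoxicity, read by resazurin assay, with a stated time of 16 h (on this read-out higher numbers stand for an effect only at larger amounts of compound and lower numbers for an effect already at smaller amounts), three compounds have been measured:

- compound 1 `COc1ccc(/C=C/C(=O)CC(=O)/C=C/c2ccc(O)c(OC)c2)cc1`: 79000 nM
- compound 2 `COc1cc(/C=C/C(=O)CC(=O)/C=C/c2ccc(OCCO)c(OC)c2)ccc1O`: 25000 nM
- compound 3 `COc1cc(/C=C/C(=O)CC(=O)/C=C/c2ccc(OCCO)c(OC)c2)ccc1OCCO`: 20000 nM

Compound 2 lies within the scatter of compound 3, while compound 1 shows the clearly higher number. The next compound to be tested is compound 4 `COc1cc(/C=C/C(=O)CC(=O)/C=C/c2ccc(OCCO)cc2)ccc1O`, which differs from compound 2 as follows: hydrogen in place of methoxy on an aromatic carbon. In short, hydrogen stands in place of methoxy on an aromatic carbon.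

For the measured compounds named here, no measured step makes this same change. Going by the values given here, the only step available, a 1.3-fold lower number from compound 2 to compound 3 (0.10 log units; within the scatter), is a different change and gives little guidance. Compound 1, at 79000 nM, also lacks this methoxy, but it differs from compound 2 elsewhere too, so it suggests only a slight lean towards higher numbers. In this assay, no step beyond the scatter is therefore expected. The expected step is a 1.3-fold higher number from compound 2 to compound 4 (0.11 log units; within the scatter). For compound 4 the estimated value is 32000 nM, with an expected range of 13000 nM to 75000 nM.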

Compound 4, half-maximal effective concentration: 46000 nM
The estimate for compound 4 lay 1.4-fold (0.16 log units) below the measured number, and the stated range covers the measured number.
By their numbers in this assay, from the lowest: compounds 3, 2, 4 and 1 (each within the scatter of the next, the first and the last beyond it).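

In this assay, for the compounds shown here, hydrogen in place of the methoxy ortho to a 2-hydroxyethoxy group gives a 1.8-fold higher number from compound 2 to compound 4 (0.26 log units; within the scatter), so this is the first direct reading of this change, and it stays inside the scatter. Hydroxymethyl in place of hydrogen on the saturated chain carbon bound to an oxygen on an aromatic ring gives a 1.7-fold lower number from compound 1 to compound 4 (0.23 log units; within the scatter), so neither single change shown here produces a step beyond the scatter. Nothing available explains these numbers.

Going by these compounds, it remains open whether an amine or an ethoxy group at this position on the aromatic ring would give a step beyond the scatter. On these data alone, it is equally open how a longer chain, or a carboxylic acid at the end of the 2-hydroxyethoxy group, would read in this assay.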